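From 2-methylphenyl to 4-fluorophenyl on an amine nitrogen

The source may report more compounds than this note shows. Statements on the series, on what has been measured and on what is new or still open speak of the compounds shown alone.

Measured so far in a functional assay on SGC-7901 cells (Homo sapiens) for antiproliferative activity, read by MTT assay, with a stated time of 24 h; on this read-out higher numbers stand for weaker inhibition and lower numbers for stronger inhibition
Compound 1 `O=C(NNc1ccccc1F)c1cccc(NS(=O)(=O)c2cnc(O)nc2O)c1` gives > 20000 nM
Compound 2 `Cc1ccccc1NNC(=O)c1ccccc1NS(=O)(=O)c1cnc(O)nc1O` gives > 20000 nM

The record so far reads the limit of > 20000 nM in this assay, at which 2 of the 2 values shown sit, and holds no number. Compound 2 stands at > 20000 nM and this is a limit, not a number. Compound 1 also gives a limit, > 20000 nM again, so no step can be read from the two measured compounds.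

Compound 3 `O=C(NNc1ccc(F)cc1)c1ccccc1NS(=O)(=O)c1cnc(O)nc1O` keeps the core of compound 2 and changes one group (4-fluorophenyl in place of 2-methylphenyl on an amine nitrogen). In words, 4-fluorophenyl stands in place of 2-methylphenyl on an amine nitrogen.

Going by the values given here, with no measured step to go on, no shift beyond the usual scatter is expected in this assay and no direction is favoured. This expectation rests on compound 2 at > 20000 nM as its only anchor. The estimated change, a step that the limit leaves unreadable from compound 2 to compound 3 (expected to stay within the scatter), is small. Compound 3 is estimated at 25000 nM with an expected range of 12000 nM to 50000 nM and another limit is the likeliest report.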

Compound 3, half-maximal inhibitory concentration: > 20000 nM
Compound 3: no number, only a limit; the forecaster's own chance of this, stated with the estimate: 75%; the middle value does not contradict the limit.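

In this assay compound 3 gives > 20000 nM, which is a limit and not a number. With compound 2 likewise reported only as a limit, no step can be read between compound 2 and compound 3. The compounds shown leave open whether any change to the shared core would give a measurable value, as all of them stand at one limit: the limit of > 20000 nM in this assay, at which 3 of the 3 values shown sit.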